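The source may hold more compounds than are shown below. What is called first, only, known or untested is meant among the compounds shown, and "the series" means these compounds.

Measured so far in a physicochemical assay for solubility, read by HPLC, in phosphate buffer, at pH 6.5; on this read-out higher numbers stand for higher solubility and lower numbers for lower solubility:
- compound 1 `COC(=O)C1=C(C)NC(c2nccs2)=NC1(C)c1ccc(F)cc1` gives 22 ug/mL
- compound 2 `COC(=O)C1=C(CN2CCNC(=O)C2)NC(c2nccs2)=NC1(C)c1ccc(F)cc1` gives 34 ug/mL
- compound 3 `COC(=O)C1=C(CN2CCC(O)C2)NC(c2nccs2)=NC1(C)c1ccc(F)cc1` gives 503 ug/mL

Compound 3 stands highest of the three numbers, with a 23-fold higher number from compound 1 to compound 3 (1.36 log units; beyond the scatter) and a 15-fold higher number from compound 2 to compound 3 (1.17 log units; beyond the scatter) both large.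

Next is compound 4 `COC(=O)C1=C(COCC(F)(F)F)NC(c2nccs2)=NC1(C)c1ccc(F)cc1`, with 2,2,2-trifluoroethoxy in place of 3-hydroxypyrrolidin-1-yl on a saturated chain carbon bound to a double-bonded ring carbon. Among the compounds with values here, no measured step brings in 2,2,2-trifluoroethoxy, so the evidence is indirect. At this same place, a 1.5-fold higher number from compound 1 to compound 2 (0.19 log units; within the scatter) stays small, which shows that a group there does not always give a large gain. The only large gains belong to 3-hydroxypyrrolidin-1-yl, which compound 4 lacks, so the expectation rests on a 23-fold higher number from compound 1 to compound 3 (1.36 log units; beyond the scatter) being lost. In this assay a large step to a lower number is expected, estimated as a 34-fold lower number from compound 3 to compound 4 (1.53 log units; beyond the scatter) in size. Compound 4 is estimated at 15 ug/mL within a range of 4 ug/mL to 50 ug/mL for now.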

Compound 4, solubility: 19 ug/mL
Compound 4: middle estimate off by 1.3-fold (0.10 log units), on the low side; low and high end bracket the measured number.
By their numbers in this assay, from the lowest: compounds 4, 1 and 2 (each within the scatter of the next); then compound 3.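

In this assay, 2,2,2-trifluoroethoxy in place of 3-hydroxypyrrolidin-1-yl gives a 26-fold lower number from compound 3 to compound 4 (1.42 log units; beyond the scatter), while in place of hydrogen it gives a 1.2-fold lower number from compound 1 to compound 4 (0.06 log units; within the scatter) and in place of 3-oxopiperazin-1-yl it gives a 1.8-fold lower number from compound 2 to compound 4 (0.25 log units; within the scatter). Compounds 1, 2 and 4 therefore read alike, and among the four compounds only compound 3 stands apart, even though the leaving and entering groups each hold 6 heavy atoms. The data available give no explanation for the gap between compound 3 and the others.

From the compounds shown here alone, it remains open whether the high number in compound 3 depends on the hydroxyl, the pyrrolidine ring or the two together; an unsubstituted pyrrolidine or a morpholine at this place would help separate these. Going by these compounds, how a carboxylic acid at this place would read in this assay also remains open.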